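The compounds below may be only part of what the source reports. "The series", "measured", "known", "first", "only" and "open" are said of these compounds alone.

Measured in a functional assay on HT-29 cells (Homo sapiens) for cytotoxicity, read by MTT assay, with a stated time of 72 h (a lower number here means a stronger inhibitor, a higher number a weaker inhibitor), so far:
compound 1 `CN(C)CCn1cnnc1-c1cc(Oc2ccc(NC(=O)N/N=C/c3cc(C(C)(C)C)cc(C(C)(C)C)c3O)cc2F)ccn1` gives 680 nM
compound 2 `COc1ccc(OC)c(/C=N/NC(=O)Nc2ccc(Oc3ccnc(-c4nncn4CCN(C)C)c3)c(F)c2)c1` gives 2070 nM
compound 3 `CN(C)CCn1cnnc1-c1cc(Oc2ccc(NC(=O)N/N=C/c3ccccc3O[N+](=O)[O-])cc2F)ccn1` gives 950 nM

Compound 2 stands at the highest number of the three in this assay. For the measured compounds named here, its nearest neighbour is compound 3, reached by a 2.2-fold lower number from compound 2 to compound 3 (0.34 log units; beyond the scatter); compound 1 lies further away, at a lower number still, though no single-point step between compound 2 and compound 1 is on record.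

Compound 4 `CN(C)CCn1cnnc1-c1cc(Oc2ccc(NC(=O)N/N=C/c3ccccc3)cc2F)ccn1` differs from compound 2 at one place only: phenyl in place of 2,5-dimethoxyphenyl on a carbon with a double bond to nitrogen. Going by the values given here, the one measured step that bears on this position is a 2.2-fold lower number from compound 2 to compound 3 (0.34 log units; beyond the scatter), where the same 2,5-dimethoxyphenyl leaves and a 2-(nitrooxy)phenyl enters; compound 1, carrying a third group at that position, also gives a lower number than compound 2. Both observations point the same way: an exchange at this carbon has so far moved the number down, modestly. For compound 4 the expectation is therefore a modest step to a lower number, a 1.6-fold lower number from compound 2 to compound 4 (0.20 log units; within the scatter), within the range spanned by compounds 1 and 3. Compound 4 is estimated at 1300 nM, with a range from 600 nM to 3000 nM.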

Compound 4, half-maximal inhibitory concentration: 1120 nM
For compound 4 the middle estimate is 1.2-fold (0.06 log units) above the measured one; low and high end bracket the measured number.
By their numbers in this assay, from the lowest: compounds 1, 3, 4 and 2 (each within the scatter of the next, the first and the last beyond it).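

Read in this assay, phenyl in place of 2,5-dimethoxyphenyl on a carbon with a double bond to nitrogen leaves compound 4 within the scatter of compound 2 (a 1.8-fold lower number from compound 2 to compound 4 (0.27 log units; within the scatter)), so the exchange of this group alone is not resolved. Hydrogen in place of nitrooxy on an aromatic carbon is likewise unresolved (a 1.2-fold higher number from compound 3 to compound 4 (0.07 log units; within the scatter)). For the compounds shown here, the one step at this position beyond the scatter (a 2.2-fold lower number from compound 2 to compound 3 (0.34 log units; beyond the scatter)) thus splits into two smaller steps through the plain phenyl of compound 4, and neither can be assigned a share of it.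

No measurement to hand accounts for these steps. Open, as far as these compounds go, is whether a group of another kind on the phenyl, such as an amine or a carboxylic acid, would give a step beyond the scatter from compound 4.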